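The source may hold more compounds than are shown below. What is called first, only, known or untested is meant among the compounds shown, and "the series" means these compounds.

In a functional assay on MV4-11 cells (Homo sapiens) for antiproliferative activity, read by luminescence and CellTiter-Glo, with a stated time of 72 h (a higher number here means a weaker inhibitor, a lower number a stronger inhibitor), compound 1 `COc1cc(F)ccc1Nc1nn(C2CCCCO2)c2cc(-c3c(C)noc3C)ccc12` gives 8500 nM. For compound 2 `COc1ccc(Cn2nc(Nc3ccc(F)cc3OC)c3cc(-c4c(C)noc4C)ccc32)cc1` the entry reads "not determined" (no result reported), so it offers no number to compare. Compound 3 `CNc1cc(-c2ccc3cnn(Cc4cc(OC)cc(OC)c4)c3c2)cn(C)c1=O` gives 190 nM, the lower of the two available numbers, and its distance from compound 1 lies beyond the scatter.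

Compound 4 `CNc1cc(-c2ccc3cnn(Cc4ccc(C(F)(F)F)cc4)c3c2)cn(C)c1=O` differs from compound 3 in one place: 4-(trifluoromethyl)phenyl in place of 3,5-dimethoxyphenyl on a saturated chain carbon bound to an aromatic nitrogen. A 4-(trifluoromethyl)phenyl stands in place of 3,5-dimethoxyphenyl on a saturated chain carbon bound to an aromatic nitrogen. Going by the values given here, no two measured compounds differ in a single place, so the data contain no direct precedent for this change, and the expectation is tentative. In this assay, a moderate rise in the number is expected, which would mean a weaker inhibitor, though a result within the scatter cannot be excluded. The expected change is a 2.6-fold higher number from compound 3 to compound 4 (0.42 log units; beyond the scatter). For compound 4 the estimated value is 500 nM, with an expected range from 130 nM to 2500 nM.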

Compound 4, half-maximal inhibitory concentration: 4370 nM
For compound 4 the middle estimate is 8.7-fold (0.94 log units) below the measured one; measured number outside the range, above it.
By their numbers in this assay, from the lowest: compound 3; then compounds 4 and 1 (each within the scatter of the next).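

Going by these compounds alone, on the saturated chain carbon bound to an aromatic nitrogen, the choice of aryl group proves decisive: in this assay, 4-(trifluoromethyl)phenyl in place of 3,5-dimethoxyphenyl gives a 23-fold higher number from compound 3 to compound 4 (1.36 log units; beyond the scatter), the first single-place comparison. The two groups match in heavy-atom count and in their one six-membered aromatic ring of carbon only, so this large step comes from an exchange that differs in the substituents on that ring and in the hydrogen-bond acceptors counted on them. No measurement is available that explains the step.

The compounds shown leave open whether the step tracks the departure of the two methoxy groups or the arrival of the trifluoromethyl, which an unsubstituted phenyl would help to separate. Also open, as far as these compounds go, is how a pyridyl group or a carboxylic acid on the phenyl would read at this position.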